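The source may report more compounds than this note shows. Statements on the series, on what has been measured and on what is new or still open speak of the compounds shown alone.

The measured compounds and their values:

compound 1, `Fc1ccc(F)c(/N=N/Nc2ccccc2)c1`: > 100000 nM
compound 2, `Fc1ccc(F)c(/N=N/Nc2cccc(C(F)(F)F)c2)c1`: > 100000 nM
compound 3, `CN(C)CCCN(/N=N/c1ccccc1)c1cccc(C(F)(F)F)c1`: 49000 nM

All three were tested in an ADME assay on BHK-21 cells (Mesocricetus auratus) for cytotoxicity, read by MTT assay, with a stated time of 96 h; a higher number here means that more compound is tolerated, a lower number that less compound is tolerated. For compound 1 the result is a limit of the assay, > 100000 nM, and not a number. For compound 2 the result is likewise a limit, > 100000 nM. Going by the values given here, only compound 3 gives a number in this assay, 49000 nM, and so it is the one value from which any expectation can start.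

Compound 1 differs from compound 2 by one change, (hydrogen in place of trifluoromethyl on an aromatic carbon), and the size of that step, a step that the two limits leave unreadable from compound 2 to compound 1, cannot be read because of the limit of > 100000 nM in this assay, at which 2 of the 3 values shown sit. The difference between the core of compound 3 and the core of compound 2 is not broken down here.

Compound 4, `CN(C)CCCN(/N=N/c1ccccc1)c1ccccc1`, has not yet been measured in this assay. It differs from compound 3 by hydrogen in place of trifluoromethyl on an aromatic carbon, which is the same change that leads from compound 2 to compound 1. Since that earlier step is unreadable, the expectation for compound 4 rests on the value of compound 3, 49000 nM, with the step from compound 3 to compound 4 estimated at a 1.4-fold higher number from compound 3 to compound 4 (0.15 log units; within the scatter). Compound 4 is therefore expected to give about 70000 nM in this assay, with a likely span from 25000 nM to 150000 nM.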

Compound 4, half-maximal cytotoxic concentration: 50000 nM
Estimate against measurement, compound 4: 1.4-fold (0.15 log units) above; measured number inside the range.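

In this assay, putting hydrogen in place of trifluoromethyl on the aromatic carbon of compound 3 gives a 1.0-fold higher number from compound 3 to compound 4 (0.01 log units; within the scatter), so on this core the change makes no difference beyond the usual scatter. The same change on the core of compound 2 cannot be read, because compound 2 and compound 1 both give a limit of the assay and not a number: the limit of > 100000 nM in this assay, at which 2 of the 4 values shown sit. This leaves one readable instance of the change, which describes the core of compound 3 alone and shows neither that the result carries over to the other core nor that it fails to do so.

The compounds shown leave open how the cells respond to other groups on that same aromatic carbon of the core of compound 3, such as a carboxylic acid, a nitrile or a methoxy group, since hydrogen and trifluoromethyl are the only two seen there. They also leave open whether the readable values on this core stay as they are when a longer chain or a primary amine takes the place of the chain that compound 3 and compound 4 share.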